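The compounds below may be only part of what the source reports. "The series", "measured", "known", "first", "only" and "open" are said of these compounds alone.

Measured so far in a functional assay, with a stated time of 30 min; a lower number here means a stronger inhibitor, a higher number a weaker inhibitor:
compound 1 `Oc1ccc(O)c(/C=N/c2ccc(OCc3ccccc3)cc2)c1` gives 21300 nM.
Compound 2 `Cc1ccc(/C=N/c2ccc(OCc3ccccc3)cc2)c(O)c1` gives only a limit of the assay, > 200000 nM.
Compound 3 `Oc1ccc(Br)cc1/C=N/c1ccc(OCc2ccccc2)cc1` likewise gives only a limit of the assay, > 200000 nM.

Compound 3 thus stands at a limit in this assay rather than at a number, and (the limit of > 200000 nM in this assay, at which 2 of the 3 values shown sit). Compound 4 `Oc1c(Br)cc(Br)cc1/C=N/c1ccc(OCc2ccccc2)cc1` differs from compound 3 by bromo in place of hydrogen on an aromatic carbon. Of the measured steps, the one that bears most on this change is an at least 9.3-fold higher number from compound 1 to compound 3 (0.97 log units; beyond the scatter), where bromo in place of hydroxy already carried the number out to the limit; the comparison a step that the two limits leave unreadable from compound 2 to compound 3 adds nothing readable. With compound 3 already at the limit, a further weakening could not be read, and nothing shown suggests a return into the measurable range. Compound 4 is therefore expected to stay at the limit in this assay, with an estimate of 300000 nM (between 100000 nM and 1000000 nM), which would amount to a step that the limit leaves unreadable from compound 3 to compound 4.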

Compound 4, half-maximal inhibitory concentration: > 200000 nM
Compound 4: no number, only a limit (the forecaster's own chance of this, stated with the estimate: 85%); the middle value lies beyond the limit too.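

Compound 3 and compound 4 both stand only at a limit in this assay, so no step can be read between them. On these data alone, whether bromo in place of hydrogen changes the inhibition at all remains open.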